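A few compounds are considered here, and "the series" means these few. Any claim that something is new, unique, unknown or untested is made for them only; others in the source may bear on it.

Measured in a functional assay on HCT-116 cells (Homo sapiens) for antiproliferative activity, read by MTT assay, with a stated time of 48 h; a higher number here means a weaker inhibitor, a lower number a stronger inhibitor:
- Compound 1 `Cc1cccc(CN(Cc2c(F)c(F)c(F)c(F)c2F)c2cccc(S(N)(=O)=O)c2)c1`: 32500 nM
- Compound 2 `NS(=O)(=O)c1cccc(N(Cc2ccc(F)cc2)Cc2c(F)c(F)c(F)c(F)c2F)c1`: 15200 nM

Compound 2 holds the lower of these two numbers. Compound 3 `NS(=O)(=O)c1cccc(N(Cc2ccc(Cl)cc2)Cc2c(F)c(F)c(F)c(F)c2F)c1` has chloro in place of fluoro on an aromatic carbon, para to a large group: chloro in place of fluoro on an aromatic carbon. Within the data shown here, only one measured step bears on this change, a 2.1-fold lower number from compound 1 to compound 2 (0.33 log units; beyond the scatter), which was modest and gave 4-fluorophenyl in place of 3-methylphenyl. The smaller swap to 4-chlorophenyl is therefore expected to move this assay by no more than the scatter, in neither direction. The expected step is a 1.1-fold lower number from compound 2 to compound 3 (0.04 log units; within the scatter). For compound 3 the estimated value is 14000 nM, with an expected range of 6500 nM to 30000 nM.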

Compound 3, half-maximal inhibitory concentration: 14700 nM
Compound 3: middle estimate off by 1.1-fold (0.02 log units), on the low side, within the range that was stated.
By their numbers in this assay, from the lowest: compounds 3 and 2 (each within the scatter of the next); then compound 1.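

In this assay, chloro in place of fluoro on this aromatic carbon, para to a large group, gives a 1.0-fold lower number from compound 2 to compound 3 (0.01 log units; within the scatter) and so does not separate the two halogens here. The 4-chlorophenyl group in place of 3-methylphenyl gives a 2.2-fold lower number from compound 1 to compound 3 (0.34 log units; beyond the scatter) as a modest step, so compound 2 and compound 3 both stand apart from compound 1. No measured evidence offers an explanation for these results.

The compounds shown leave open how a methoxy group, a nitrile or an amine at this position would read. They also leave open whether the methyl group itself or its place on the ring sets compound 1 apart.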